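A few compounds are considered here, and "the series" means these few. Any claim that something is new, unique, unknown or untested is made for them only; others in the source may bear on it.

Measured compounds: compound 1 `C/C=C/C=C/C(=O)N[C@H](C(=O)NCCCCCCCC)[C@@H](C)O`, compound 2 `CCCCCCCCCCCCCCNC(=O)[C@@H](NC(=O)c1ccccc1)[C@@H](C)O`, compound 3 `CCCCCCCCCCCCCCNC(=O)[C@@H](NC(=O)c1cc2ccccc2n1C)[C@@H](C)O`.

In a functional assay on MCF7 cells (Homo sapiens) for cytotoxicity, read by MTT assay, with a stated time of 48 h (a higher number here means a weaker inhibitor, a lower number a stronger inhibitor), compound 1 gives 149000 nM, compound 2 gives 24800 nM and compound 3 gives 25700 nM. Compound 3 thus stands close to compound 2, separated from it by a 1.0-fold higher number from compound 2 to compound 3 (0.02 log units; within the scatter), and far from compound 1. Compound 4 `C/C=C/C=C/C(=O)N[C@H](C(=O)NCCCCCCCCCCCCCC)[C@@H](C)O` is made from compound 3 by penta-1,3-dien-1-yl in place of 1-methyl-1H-indol-2-yl on a carbonyl carbon. Within the data shown here, no measured step covers this exact change. The step of a 1.0-fold higher number from compound 2 to compound 3 (0.02 log units; within the scatter) shows that one acyl swap on this carbonyl carbon left the number unchanged, while compound 1, which carries the same penta-1,3-dien-1-yl group but differs from compound 4 elsewhere too, gave a much higher number. The estimate for compound 4 in this assay is therefore 60000 nM (range 20000 nM to 200000 nM), a step of a 2.3-fold higher number from compound 3 to compound 4 (0.37 log units; beyond the scatter) expected towards a higher number.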

Compound 4, half-maximal inhibitory concentration: 27800 nM
Compound 4: the middle estimate sits 2.2-fold (0.33 log units) above what was measured; measured number inside the range.
By their numbers in this assay, from the lowest: compounds 2, 3 and 4 (each within the scatter of the next); then compound 1.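

In this assay the group on this carbonyl carbon, whose other neighbour is an amide-type nitrogen, shows no effect beyond the scatter: penta-1,3-dien-1-yl gives a 1.1-fold higher number from compound 3 to compound 4 (0.03 log units; within the scatter) and a 1.1-fold higher number from compound 2 to compound 4 (0.05 log units; within the scatter). Among these compounds, with penta-1,3-dien-1-yl held constant, hexyl in place of hydrogen on a saturated chain carbon, eight bonds along the chain from an amide-type nitrogen, gives a 5.4-fold lower number from compound 1 to compound 4 (0.73 log units; beyond the scatter), the only one of these single changes beyond the scatter. Nothing available accounts for either result. Still open, from the compounds shown here alone, is whether an amine or a carboxylic acid on this carbonyl carbon, or a chain longer than that of compound 4, would shift the number.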